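Replacing the nitrile on the piperazine aryl: compound 2 to compound 4

The source may report more compounds than this note shows. Statements on the series, on what has been measured and on what is new or still open speak of the compounds shown alone.

Compound 2 `Cc1nc(-c2ccccc2)c(C(=O)N2CCN(c3cccc(C#N)c3)CC2)o1` is the weakest of the three measured compounds in an ADME assay on microsomes from liver (Mus musculus) for metabolic stability, read by LC-MS, with a stated time of 1 h, tested at 5 uM; on this read-out higher numbers stand for a more stable compound and lower numbers for a less stable compound: compound 2 gives 1.6%. Going by the values given here, compound 1 `Cc1nc(-c2ccccc2F)c(C(=O)N2CCN(c3cc(Cl)cc(Cl)c3)CC2)o1` gives 49% in this assay, and compound 3 `Cc1nc(-c2cccc(F)c2)c(C(=O)N2CCN(c3cc(Cl)cc(Cl)c3)CC2)o1` gives 40.7%; both sit far above compound 2, beyond the scatter, while the only measured step, a number 8.3 percentage points lower from compound 1 to compound 3 (within the scatter), lies within the scatter and concerns a different place in the molecule.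

Compound 4 `Cc1cc(C)cc(N2CCN(C(=O)c3oc(C)nc3-c3ccccc3)CC2)c1` is compound 2 with 3,5-dimethylphenyl in place of 3-cyanophenyl on an amine nitrogen in a ring. No measured step touches this position, so nothing among the shown steps bears directly on it; the sole pointer is that compound 1 and compound 3 carry a different group on that same ring nitrogen and stand well above compound 2 in this assay. Compound 4 is therefore expected to move upward, a number 16.4 percentage points higher from compound 2 to compound 4 (beyond the scatter), with wide uncertainty. The estimate for compound 4 in this assay is 18%, within a range from 3% to 45%.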

Compound 4, percent of the compound remaining: 12%
The estimate for compound 4 lay 6 percentage points above the measured number; low and high end bracket the measured number.
By their numbers in this assay, from the lowest: compound 2; then compound 4; then compounds 3 and 1 (each within the scatter of the next).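

In this assay, the first step read at this position is a number 10.4 percentage points higher from compound 2 to compound 4 (beyond the scatter), which shows that the group on the amine nitrogen in a ring can shift the number on the core of compound 2. The step is modest, and it comes with 3,5-dimethylphenyl in place of 3-cyanophenyl, a change that removes the nitrile and adds two methyl groups while keeping a six-membered aromatic ring of carbon only. Nothing available explains the step.

Going by these compounds, whether the loss of the nitrile or the gain of the methyl groups carries the step stays open, since the two changes travel together in compound 4. Also open, on these data alone, is how a methoxy group or a primary amine on this aryl ring would read in this assay.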